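The source may report more compounds than this note shows. Statements on the series, on what has been measured and on what is new or still open speak of the compounds shown alone.

Measured in a functional assay on A549 cells (Homo sapiens) for inhibition, read by CCK-8 assay, with a stated time of 72 h, tested at 2 uM; on this read-out higher numbers stand for more inhibition of growth at the one concentration tested and lower numbers for less inhibition of growth:
compound 1 `Nc1ccccc1NC(=O)/C=C/c1ccc(CSc2ccc(Cl)cc2)cc1` gives 55.3%
compound 2 `Cc1ccc(SCc2ccc(C(=O)Nc3ccccc3N)cc2)cc1` gives 40.5%
compound 3 `CC(C)(C)c1ccc(SCc2ccc(C(=O)Nc3ccccc3N)cc2)cc1` gives 38.6%

In this assay compound 2 stands second highest of the three numbers; compound 3 sits nearest, a number 1.9 percentage points lower from compound 2 to compound 3 (within the scatter), and compound 1 sits furthest, its number higher than that of compound 2 by more than the scatter.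

Compound 4 `Nc1ccccc1NC(=O)c1ccc(CSCCc2ccccc2)cc1` differs from compound 2 in one place: phenethyl in place of 4-methylphenyl on a sulfur.

For the measured compounds named here, the only measured single-place step, a number 1.9 percentage points lower from compound 2 to compound 3 (within the scatter), alters a substituent on the sulfur-bound aromatic group rather than exchanging that group, so it bears on the present change only loosely, and it was within the scatter. Going by the values given here, no measured step covers an exchange of this kind. The expected step is therefore none beyond the scatter, a number 0.5 percentage points lower from compound 2 to compound 4 (within the scatter). For compound 4 the estimate is 40%, with a range from 25% to 55%.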

Compound 4, percent growth inhibition at one concentration: 44.9%
The estimate for compound 4 lay 4.9 percentage points below the measured number, and the stated range covers the measured number.
By their numbers in this assay, from the lowest: compounds 3, 2 and 4 (each within the scatter of the next); then compound 1.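

In this assay the exchange of 4-methylphenyl for phenethyl on a sulfur gives a number 4.4 percentage points higher from compound 2 to compound 4 (within the scatter) and so shows that this position accepts a change of the whole group, not only of a substituent on it. The aromatic ring need not be bound directly to the sulfur for the number to stay within the scatter at this one concentration. No measured evidence bears on why this step is small.

Going by these compounds, how a longer chain, or an amine or carboxylic acid on the sulfur, would read stays open. On these data alone, whether the same picture holds at other concentrations also stays open.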